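The source may hold more compounds than are shown below. What is called first, only, known or untested is meant among the compounds shown, and "the series" means these compounds.

Compound 1 `CCCCN(CCCC)c1nc2c(ncn2-c2ccccc2)c(=O)n1-c1ccccc1`; compound 2 `O=c1c2ncn(-c3ccccc3)c2nc(N2CCCCC2)n1-c1ccc(Cl)cc1`; compound 3 `CNc1nc2c(ncn2-c2ccccc2)c(=O)n1-c1ccccc1`.

In a functional assay on OVCAR-3 cells (Homo sapiens) for cytotoxicity, read by MTT assay, with a stated time of 72 h (on this read-out higher numbers stand for weaker inhibition and lower numbers for stronger inhibition), compound 1 gives 10000 nM. For compound 2 only a limit is reported, > 100000 nM. For compound 3 the value is also a limit, > 100000 nM. Compound 2 therefore stands at the top of what this assay reports, sharing (the limit of > 100000 nM in this assay, at which 2 of the 3 values shown sit). Compound 4 `O=c1c2ncn(-c3ccccc3)c2nc(NCc2ccccc2)n1-c1ccc(Cl)cc1` is the next compound, and it differs from compound 2 by benzylamino in place of piperidin-1-yl on an aromatic carbon. Within the data shown here, the one measured step on this carbon, an at least 10-fold higher number from compound 1 to compound 3 (1.00 log units; beyond the scatter), is of a different kind and gives no direct guide, so no step beyond the scatter is expected. Compound 4 is estimated at 100000 nM, between 30000 nM and 300000 nM, the expected step being a number no higher from compound 2 to compound 4 (the limit leaves the size open).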

Compound 4, half-maximal inhibitory concentration: 46700 nM
Beside the measured number, compound 4's estimate is 2.1-fold (0.33 log units) above it, and the stated range covers the measured number.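

In this assay, the carbon between two ring nitrogen atoms also responds to a change when the 4-chlorophenyl group is present: the step with benzylamino in place of piperidin-1-yl is an at least 2.1-fold lower number from compound 2 to compound 4 (0.33 log units; beyond the scatter). The earlier step at this carbon involved only open-chain amino groups, whereas this one replaces a ring amine with benzylamino. The value of compound 2 is a limit, so the true size of the step stays open: the limit of > 100000 nM in this assay, at which 2 of the 4 values shown sit.

The compounds shown leave open what the 4-chlorophenyl group itself contributes. They also leave open whether a phenethylamino or morpholin-4-yl group on this carbon would lower the number further.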